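The source may hold more compounds than are shown below. What is called first, only, known or untested is meant among the compounds shown, and "the series" means these compounds.

In a functional assay on SMMC-7721 cells (Homo sapiens) for cytotoxicity, read by MTT assay, with a stated time of 72 h (a lower number here means a stronger inhibitor, a higher number a weaker inhibitor), compound 1 `COc1ccc(C=C2C(=O)N(c3ccc(Cl)cc3)N(c3ccc(Cl)cc3)C2=O)cc1OC` reads > 128000 nM, which is a limit of the assay. Among the compounds with values here, compound 2 `O=C1C(=Cc2ccc(F)cc2F)C(=O)N(c2ccc(Cl)cc2)N1c1ccc(Cl)cc1` gives 35800 nM, the only actual number so far. Compound 3 `O=C1C(=Cc2c[nH]c3ccccc23)C(=O)N(c2ccc(Cl)cc2)N1c1ccc(Cl)cc1` differs from compound 2 by 1H-indol-3-yl in place of 2,4-difluorophenyl on a double-bonded chain carbon bound to a double-bonded ring carbon. Within the data shown here, the one measured step at this place, an at least 3.5-fold lower number from compound 1 to compound 2 (0.55 log units; beyond the scatter), shows that the group there can shift the read-out, but it does not show what 1H-indol-3-yl will do. No change beyond the scatter is therefore expected, and the estimated step is a 1.4-fold lower number from compound 2 to compound 3 (0.16 log units; within the scatter). The estimated value for compound 3 is 25000 nM, with an expected range from 6000 nM to 100000 nM.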

Compound 3, half-maximal inhibitory concentration: 19600 nM
Beside the measured number, compound 3's estimate is 1.3-fold (0.11 log units) above it; measured number inside the range.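

In this assay, the place on the double-bonded chain carbon takes 1H-indol-3-yl as well as 2,4-difluorophenyl, two groups with different ring counts and hydrogen-bond donors, with no change beyond the scatter: a 1.8-fold lower number from compound 2 to compound 3 (0.26 log units; within the scatter). Replacing 3,4-dimethoxyphenyl with 1H-indol-3-yl gives an at least 6.5-fold lower number from compound 1 to compound 3 (0.81 log units; beyond the scatter), so a second group now stands clear of the dimethoxy compound. This comparison rests on a limit for compound 1: the limit of > 128000 nM in this assay, at which 1 of the 3 values shown sits.

On these data alone, the true size of the gap to compound 1 remains open. So does what an amine or a carboxylic acid at this place would do, and whether the hydrogen-bond donor of 1H-indol-3-yl matters at all.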